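A few compounds are considered here, and "the series" means these few. Any claim that something is new, unique, unknown or untested is made for them only; others in the source may bear on it.

Measured compounds in a functional assay on HT-29 cells (Homo sapiens) for cytotoxicity, read by MTT assay, with a stated time of 24 h; on this read-out higher numbers stand for weaker inhibition and lower numbers for stronger inhibition:
compound 1 `Cn1c(-c2ccc(NC(=O)CCl)cc2)nc(-c2ccccc2)c1-c1ccccc1` gives 28.7 ug/mL;
compound 2 `Cn1c(-c2ccc(NC(=O)CSc3nc4ccccc4s3)cc2)nc(-c2ccccc2)c1-c1ccccc1` gives 18 ug/mL;
compound 3 `CN1CCN(CC(=O)Nc2ccc(-c3nc(-c4ccccc4)c(-c4ccccc4)n3C)cc2)CC1` gives 35.5 ug/mL.

Compound 3 returns the highest of the three numbers, but the step of a 1.2-fold higher number from compound 1 to compound 3 (0.09 log units; within the scatter) and the step of a 2.0-fold higher number from compound 2 to compound 3 (0.29 log units; within the scatter) both stay within the scatter, so no order among the three can be read from these values. The remaining step, a 1.6-fold lower number from compound 1 to compound 2 (0.20 log units; within the scatter), is likewise within the scatter.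

Compound 4 `CN(C)/C=C/N1CCN(CC(=O)Nc2ccc(-c3nc(-c4ccccc4)c(-c4ccccc4)n3C)cc2)CC1` differs from compound 3 in one place: 2-(dimethylamino)ethenyl in place of methyl on an amine nitrogen in a ring. None of the three measured steps touches the amine nitrogen in the ring; each of them exchanges the group on the saturated chain carbon bound to the carbonyl carbon, and each stays within the scatter. Within the data shown here, the data therefore give no direct precedent for the change to compound 4, and no step beyond the scatter is expected in this assay.

Compound 4 is estimated at 30 ug/mL, with a range from 12 ug/mL to 75 ug/mL, which means an expected step of a 1.2-fold lower number from compound 3 to compound 4 (0.07 log units; within the scatter).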

Compound 4, half-maximal inhibitory concentration: 80 ug/mL
Compound 4: the middle estimate sits 2.7-fold (0.43 log units) below what was measured, outside the stated range (above it).
By their numbers in this assay, from the lowest: compounds 2, 1 and 3 (each within the scatter of the next); then compound 4.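

In this assay, the amine nitrogen in the ring proves sensitive to substitution: 2-(dimethylamino)ethenyl in place of methyl gives a 2.3-fold higher number from compound 3 to compound 4 (0.35 log units; beyond the scatter) and so goes beyond the scatter, which none of the three earlier exchanges on the saturated chain carbon did. The same group also sets this compound apart from the chloro and (1,3-benzothiazol-2-yl)sulfanyl compounds, with a 2.8-fold higher number from compound 1 to compound 4 (0.45 log units; beyond the scatter) and a 4.4-fold higher number from compound 2 to compound 4 (0.65 log units; beyond the scatter), making compound 4 the weakest inhibitor of the four on this read-out. Nothing available here explains this step.

As far as these compounds go, it remains open whether the step follows from the added heavy atoms, the double bond or the dimethylamino nitrogen. A plain ethyl group or a saturated 2-(dimethylamino)ethyl group on the same nitrogen would help to separate these possibilities.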